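Benzylamine variations on a shared diamine core

A few compounds are considered here, and "the series" means these few. Any claim that something is new, unique, unknown or untested is made for them only; others in the source may bear on it.

Measured so far:
compound 1, `COc1ccc(CNc2nc3cc(N)cc(N)c3nc2-c2ccccc2)cc1OC`: 12900 nM
compound 2, `Nc1cc(N)c2nc(-c3ccccc3)c(NCc3ccc(F)cc3)nc2c1`: 2040 nM

Within the data shown here, in a functional assay on UACC-257 cells (Homo sapiens) for inhibition, read by sulforhodamine B assay, with a stated time of 48 h (on this read-out higher numbers stand for weaker inhibition of growth and lower numbers for stronger inhibition of growth), compound 2 gives 2040 nM, the lower of the two numbers; its only neighbour, compound 1, gives 12900 nM, higher by a 6.3-fold lower number from compound 1 to compound 2 (0.80 log units; beyond the scatter). Compound 3, `COc1ccc(CNc2nc3cc(N)cc(N)c3nc2-c2ccccc2)cc1`, has not yet been tested. Its change from compound 2 is methoxy in place of fluoro on an aromatic carbon; cut one bond further out, the change reads 4-fluorobenzyl to 4-methoxybenzyl. Among the measured compounds shown here, the one measured step that bears on it is the move from 3,4-dimethoxyphenyl to 4-fluorophenyl on the same saturated chain carbon, a 6.3-fold lower number from compound 1 to compound 2 (0.80 log units; beyond the scatter). Compound 3 keeps one of the two methoxy groups of compound 1 and drops the fluoro of compound 2, so structurally it lies between the two measured compounds. A single step cannot separate the share of the second methoxy from that of the fluoro, so the number for compound 3 is expected to land between the two measured values. Compound 3 is estimated at 5000 nM, with a range of 2000 nM to 13000 nM, which would mean an expected step of a 2.5-fold higher number from compound 2 to compound 3 (0.39 log units; beyond the scatter).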

Compound 3, concentration for 50% growth inhibition: 16200 nM
Beside the measured number, compound 3's estimate is 3.2-fold (0.51 log units) below it; measured number outside the range, above it.
By their numbers in this assay, from the lowest: compound 2; then compounds 1 and 3 (each within the scatter of the next).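

In this assay, methoxy in place of fluoro on the aromatic carbon para to a large group gives a 7.9-fold higher number from compound 2 to compound 3 (0.90 log units; beyond the scatter), so this single exchange is enough to produce a step beyond the scatter, which the earlier comparison, with two methoxy groups changing at once, could not isolate. Hydrogen in place of the second methoxy gives a 1.3-fold higher number from compound 1 to compound 3 (0.10 log units; within the scatter), so that group makes no readable difference here, and within these three compounds the fluoro of compound 2 is what sets it apart from the two methoxy-bearing compounds. Nothing available explains why fluoro and methoxy differ at this carbon.

The compounds shown do not tell whether the lower number of compound 2 belongs to fluoro itself or simply to the absence of a methoxy at this carbon, a question that an unsubstituted benzyl, chloro, trifluoromethyl or an amine at the same carbon would address. Going by these compounds, it also remains open whether the gap between the fluoro and methoxy compounds holds with a longer chain between the nitrogen and the aromatic ring.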